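The compounds below may be only part of what the source reports. "The series", "measured", "known", "first", "only" and "open" are said of these compounds alone.

Within the data shown here, compound 2 `N#CC1=C(N)Oc2c(c3nc4ccccc4nc3c3ccccc23)C12C(=O)N(Cc1cnnn1-c1cccc(Cl)c1)c1ccccc12` is the one member of this small set with a number: in a functional assay on A549 cells (Homo sapiens) for antiproliferative activity, read by MTT assay, with a stated time of 48 h (a lower number here means a stronger inhibitor, a higher number a weaker inhibitor), compound 2 gives 32600 nM. Compound 1 `Cc1ccccc1-n1nncc1CN1C(=O)C2(C(C#N)=C(N)Oc3c2c2nc4ccccc4nc2c2ccccc32)c2ccccc21` reaches only a limit of > 50000 nM in this assay. Compound 3 `CCOc1ccccc1-n1nncc1CN1C(=O)C2(C(C#N)=C(N)Oc3c2c2nc4ccccc4nc2c2ccccc32)c2ccccc21` likewise reaches only a limit of > 50000 nM. Compound 4 `N#CC1=C(N)Oc2c(c3nc4ccccc4nc3c3ccccc23)C12C(=O)N(Cc1cnnn1-c1ccc(S(N)(=O)=O)cc1)c1ccccc12` differs from compound 2 by 4-sulfamoylphenyl in place of 3-chlorophenyl on an aromatic nitrogen. The two measured steps that touch this position, an at least 1.5-fold lower number from compound 1 to compound 2 (0.18 log units; that floor lies within the scatter) and an at least 1.5-fold higher number from compound 2 to compound 3 (0.18 log units; that floor lies within the scatter), each rest on (the limit of > 50000 nM in this assay, at which 2 of the 3 values shown sit), so neither gives a readable size. Among the measured compounds shown here, no measured step places a 4-sulfamoylphenyl on this aromatic nitrogen, and a step of no size beyond the scatter is expected a 1.2-fold higher number from compound 2 to compound 4 (0.07 log units; within the scatter). Compound 4 is therefore estimated at 38000 nM, between 12000 nM and 60000 nM.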

Compound 4, half-maximal inhibitory concentration: > 50000 nM
Compound 4: only a limit was reported; the forecaster's own chance of this, stated with the estimate: 45%; at least 1.3-fold (0.11 log units) between middle value and limit.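

In this assay compound 4 gives only a limit, > 50000 nM, so 4-sulfamoylphenyl on this aromatic nitrogen does not yield a measurable number. The change is recorded as an at least 1.5-fold higher number from compound 2 to compound 4 (0.18 log units; that floor lies within the scatter), and the steps linking compound 4 to compound 1 and compound 3 cannot be read. Compound 2 remains the only member with a number, and the size of every change at this position stays unknown: the limit of > 50000 nM in this assay, at which 3 of the 4 values shown sit.

Going by these compounds, it remains open whether an unsubstituted phenyl, a pyridyl or a phenyl carrying a carboxylic acid on this aromatic nitrogen would give a number in this assay.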